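This account rests on a few compounds, and the source may have more. Where it says the series, first, only, none or still open, it means among the compounds named here.

Measured so far:
compound 1 `CSc1ccccc1NC(=O)Nc1cc(C)nc2ccccc12` — > 25000 nM
compound 2 `Cc1cc(NC(=O)Nc2ccc(OC(F)(F)F)cc2)c2ccccc2n1` — 10000 nM

In an ADME assay on Raji cells (Homo sapiens) for cytotoxicity, with a stated time of 72 h (a higher number here means that more compound is needed for the effect, a lower number that less compound is needed), compound 1 gives only a limit, > 25000 nM, so its place on the scale is not fixed; it sits at the limit of > 25000 nM in this assay, at which 1 of the 2 values shown sits. Compound 2 gives 10000 nM in this assay. Compound 3 `Cc1cc(NC(=O)Nc2ccccc2F)c2ccccc2n1` differs from compound 1 by fluoro in place of methylsulfanyl on an aromatic carbon, placed on an aromatic carbon of a six-membered aromatic ring of carbon only, ortho to a large group. Among the measured compounds shown here, with no measured step to lean on, no change beyond the scatter is expected; the step of an at least 1.2-fold lower number from compound 1 to compound 3 (0.09 log units; that floor lies within the scatter) is an estimate only. Compound 3 is expected at 20000 nM, within 7000 nM to 60000 nM.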

Compound 3, half-maximal effective concentration: > 25000 nM
Compound 3: a limit, no number; the forecaster's own chance of this, stated with the estimate: 55%; at least 1.2-fold (0.09 log units) between middle value and limit.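

Among the compounds shown here, compound 1 and compound 3 both stand only as limits, so no step between them can be read: the limit of > 25000 nM in this assay, at which 2 of the 3 values shown sit. Going by these compounds, whether fluoro in place of methylsulfanyl on an aromatic carbon shifts the number at all stays open.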